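A few compounds are considered here, and "the series" means these few. Any claim that something is new, unique, unknown or untested is made for them only; others in the source may bear on it.

Measured so far in an assay on SH-SY5Y cells for inhibition of Voltage-dependent N-type calcium channel subunit alpha-1B (Homo sapiens), read by FLIPR and calcium flux, with stated times of 600 s and 300 s, in the presence of a further agent that is not named here; on this read-out lower numbers stand for stronger inhibition and higher numbers for weaker inhibition:
compound 1 `CN(C)CCCOc1ccc(CNc2nc3ccc(Oc4cccc(C(F)(F)F)c4)cc3s2)cc1`: 51000 nM
compound 2 `CN(C)CCCOc1ccc(CNc2nc3ccc(Oc4ccc(F)cc4)cc3s2)cc1`: 40000 nM
compound 3 `CN(C)CCCOc1ccc(CNc2nc3ccc(Oc4ccc(C#N)cc4)cc3s2)cc1`: 105000 nM

Compound 1 stands second highest of the three numbers. Its nearest neighbour is compound 2, with a 1.3-fold lower number from compound 1 to compound 2 (0.11 log units; within the scatter), a step within the scatter; its furthest is compound 3, with a 2.1-fold higher number from compound 1 to compound 3 (0.31 log units; beyond the scatter). Between the other two the step is a 2.6-fold higher number from compound 2 to compound 3 (0.42 log units; beyond the scatter). Every measured step exchanges the aryl group on the oxygen on the aromatic ring of the shared core, and the chain with its terminal amine is the same in all three.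

Compound 4 `NCCCOc1ccc(CNc2nc3ccc(Oc4cccc(C(F)(F)F)c4)cc3s2)cc1` differs from compound 1 by amino in place of dimethylamino on a saturated chain carbon, three bonds along the chain from an oxygen on an aromatic ring. Going by the values given here, no measured step bears on this change: the aryl group on the oxygen is kept as in compound 1, and no measured pair varies the amine on the chain. The step expected from compound 1 to compound 4 in this assay is therefore no change at the digits printed from compound 1 to compound 4 (within the scatter), none beyond the scatter. Compound 4 is estimated at 51000 nM, with a range from 18000 nM to 140000 nM.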

Compound 4, half-maximal inhibitory concentration: 144000 nM
Compound 4: middle estimate off by 2.8-fold (0.45 log units), on the low side; measured number outside the range, above it.
By their numbers in this assay, from the lowest: compounds 2 and 1 (each within the scatter of the next); then compounds 3 and 4 (each within the scatter of the next).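

In this assay the amine end of the chain is a place that moves the number, since amino in place of dimethylamino gives a 2.8-fold higher number from compound 1 to compound 4 (0.45 log units; beyond the scatter). Going by these compounds alone, all earlier steps exchanged the aryl group on the oxygen, so this is the first reading at the chain end, and it shows weaker inhibition once the methyl groups on the nitrogen are gone. No measurement at hand gives a reason for this step.

Open, as far as these compounds go, is whether both methyl groups matter, or the amine's shape more broadly; a methylamino, pyrrolidine or morpholine group on the same chain, or a longer chain, would separate these. Also open, from the compounds shown here alone, is whether the same amine change carries the same step with the 4-fluorophenyl or 4-cyanophenyl group on the oxygen.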